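From piperidin-4-yl to furan-2-yl on the shared core

The source may hold more compounds than are shown below. What is called first, only, known or untested is meant among the compounds shown, and "the series" means these compounds.

Compound 1 `CC(O)c1cc(NCc2cccnc2)n2ncc(Br)c2n1`: 1400 nM
Compound 2 `Brc1cnn2c(NCc3cccnc3)cc(C3CCCCC3)nc12`: 200 nM
Compound 3 `Brc1cnn2c(NCc3cccnc3)cc(C3CCNCC3)nc12`: 160 nM

These numbers come from a functional assay on cells (Homo sapiens), read by thymidine incorporation (on this read-out higher numbers stand for weaker inhibition and lower numbers for stronger inhibition), and the three compounds share one core. Compound 3 sits at the low end together with compound 2 and well clear of compound 1. The gap between those two low values is a 1.3-fold lower number from compound 2 to compound 3 (0.10 log units; within the scatter) and so no real difference, while an 8.8-fold lower number from compound 1 to compound 3 (0.94 log units; beyond the scatter) marks a true one.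

Compound 4 `Brc1cnn2c(NCc3cccnc3)cc(-c3ccco3)nc12` has not been measured yet. It carries furan-2-yl in place of piperidin-4-yl on an aromatic carbon, and nothing else changes.

The useful guides are the swaps at this same carbon. Cyclohexyl in place of 1-hydroxyethyl gave a 7.0-fold lower number from compound 1 to compound 2 (0.85 log units; beyond the scatter) as a clear gain. Going by the values given here, no compound measured so far has an aromatic ring at this carbon, so the data give no direct guide to furan-2-yl. Going by a 1.3-fold lower number from compound 2 to compound 3 (0.10 log units; within the scatter) as the only swap of one ring for another, no large change is expected in this assay, at most a small drift toward a higher number. The estimated step is a 1.8-fold higher number from compound 3 to compound 4 (0.24 log units; within the scatter) and carries real uncertainty. For compound 4 the estimated value is 280 nM with an expected range from 80 nM to 950 nM in this measurement.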

Compound 4, half-maximal inhibitory concentration: 15200 nM
Compound 4: the middle estimate sits 54-fold (1.73 log units) below what was measured; measured number outside the range, above it.
By their numbers in this assay, from the lowest: compounds 3 and 2 (each within the scatter of the next); then compound 1; then compound 4.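

This carbon of the shared core does not accept every ring alike: in this assay, cyclohexyl and piperidin-4-yl give values within the scatter of each other (a 1.3-fold lower number from compound 2 to compound 3 (0.10 log units; within the scatter)), yet furan-2-yl brings a far higher number (a 95-fold higher number from compound 3 to compound 4 (1.98 log units; beyond the scatter); a 76-fold higher number from compound 2 to compound 4 (1.88 log units; beyond the scatter)). Having a ring at this carbon is therefore not enough for a low number, since the furan-2-yl compound also ends up on the weak side of the open-chain 1-hydroxyethyl compound (an 11-fold higher number from compound 1 to compound 4 (1.04 log units; beyond the scatter)), reversing the gain that the two six-membered non-aromatic rings showed over that group. Nothing available here accounts for this sharp loss.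

The change from piperidin-4-yl to furan-2-yl alters ring size and aromatic character together, so the compounds shown cannot tell which of the two goes with the higher number. A phenyl group, which is aromatic but six-membered, or a pyrrolidin-3-yl group, which is five-membered but non-aromatic, would pull those two features apart at this carbon.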